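The source may report more compounds than this note shows. Statements on the series, on what has been measured and on what is new or still open speak of the compounds shown alone.

Two members of this series have numbers in a functional assay on SN12C cells (Homo sapiens) for inhibition, read by sulforhodamine B assay, with a stated time of 48 h, tested at 10 uM; on this read-out higher numbers stand for more inhibition of growth at the one concentration tested and lower numbers for less inhibition of growth. Compound 1 `CCOC(=O)c1ccc(Nc2ccnc(SCC(=O)c3ccc([N+](=O)[O-])cc3)n2)cc1` gives 17% in this assay. Compound 2 `CC(=O)c1cccc(Nc2ccnc(SCC(=O)c3ccc(-c4ccccc4)cc3)n2)c1` gives 13% in this assay. Those two numbers sit within the scatter of each other, so compound 2 cannot be set apart from compound 1 on these data; both sit at the low end of the read-out, and neither reaches a level that would count as marked growth inhibition at this single concentration.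

Compound 3 `COc1ccc(C(=O)CSc2nccc(Nc3cccc(C(C)=O)c3)n2)cc1` has not been measured. It differs from compound 2 in one place: methoxy in place of phenyl on an aromatic carbon. Everything else in the shared core is kept. Among the compounds with values here, no pair of measured compounds differs by only this change, so there is no measured step to lean on. Within the data shown here, with only two low numbers in hand and nothing to show that this position moves the read-out, the expected step from compound 2 to compound 3 is a number 1 percentage points higher from compound 2 to compound 3 (within the scatter), that is, none beyond the scatter. Compound 3 is estimated at 14%, with a range from 3% to 27%.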

Compound 3, percent growth inhibition at one concentration: 22%
For compound 3 the middle estimate is 8 percentage points below the measured one; the range from low to high includes it.
By their numbers in this assay, from the lowest: compounds 2, 1 and 3 (each within the scatter of the next).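

In this assay the exchange of phenyl for methoxy on the aromatic carbon para to a large group gives a number 9 percentage points higher from compound 2 to compound 3 (within the scatter) and so does not set the two groups apart. Within the data shown here, this is the first measured step at this position: a six-membered aromatic ring of carbon only gives way to a group of two heavy atoms with one hydrogen-bond acceptor, and the read-out shows no change beyond the scatter, though only at the low end of the read-out and at the one concentration tested. No measurement bears on the size of this step, and no cause can be assigned to it.

Going by these compounds, whether any other group at this position, such as an amine, a carboxylic acid or a longer alkoxy chain, would move the number beyond the scatter remains open. Also open, on these data alone, is whether the exchange of phenyl for methoxy would give a similar step with another part of the shared core changed, since the present step rests on a single pair of compounds.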